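The source may report more compounds than this note shows. Statements on the series, on what has been measured and on what is new or still open speak of the compounds shown alone.

Values in a functional assay on HCT-116 cells (Homo sapiens) for cytotoxicity, read by MTT assay, with a stated time of 72 h (on this read-out higher numbers stand for weaker inhibition and lower numbers for stronger inhibition), so far

Compound 1 `O=C1C=CCC/C1=C\C=C\c1ccccc1` gives 5400 nM

Compound 2 `CC(=C\c1ccccc1)/C=C1\CCC=CC1=O` gives 4800 nM

Compound 3 `O=C1C=CCC/C1=C\C=C\c1ccc(F)cc1` gives 2200 nM

Compound 1 sits at the upper end of these numbers together with compound 2, with no order between the two, and compound 3 lies lower. Compound 4 `O=C1C=CCC/C1=C\C=C\c1ccc([N+](=O)[O-])cc1` departs from compound 1 by a single change, nitro in place of hydrogen on an aromatic carbon (nitro in place of hydrogen on an aromatic carbon, para to a large group).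

The closest measured change is the fluoro one, a 2.5-fold lower number from compound 1 to compound 3 (0.39 log units; beyond the scatter) (fluoro in place of hydrogen on an aromatic carbon), a modest step. The other measured change, a 1.1-fold lower number from compound 1 to compound 2 (0.05 log units; within the scatter) (methyl in place of hydrogen on a double-bonded chain carbon), lies on the chain rather than the aromatic ring and offers little guidance here. Among the measured compounds shown here, no nitro compound has been measured, and the aromatic evidence rests on compound 3 alone, so the range stays wide and reaches back to the value of the parent.

A step of similar modest size towards a lower number is expected, estimated as a 2.7-fold lower number from compound 1 to compound 4 (0.43 log units; beyond the scatter) in this assay on this single precedent. For compound 4 the estimated value is 2000 nM with an expected range from 700 nM to 5500 nM.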

Compound 4, half-maximal inhibitory concentration: 5000 nM
For compound 4 the middle estimate is 2.5-fold (0.40 log units) below the measured one; the range from low to high includes it.
By their numbers in this assay, from the lowest: compound 3; then compounds 2, 4 and 1 (each within the scatter of the next).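

In this assay the aromatic carbon para to a large group does not answer alike to every replacement of hydrogen: the nitro change gives a 1.1-fold lower number from compound 1 to compound 4 (0.03 log units; within the scatter) and leaves compound 4 level with the parent, while the swap of fluoro for nitro at the same carbon gives a 2.3-fold higher number from compound 3 to compound 4 (0.36 log units; beyond the scatter) and is a modest step. The lower number of compound 3 therefore does not extend to this second group, so a substituent at this place is not enough in itself to move the value beyond the scatter from compound 1, and among the ring changes shown that lower number belongs to the fluoro group alone. Nothing measured alongside these values explains why the fluoro and nitro groups part here.

Among the compounds shown here, with only two groups at this carbon, the series gives no basis for a trend across substituents, and it remains open whether chloro, methoxy, an amine or a carboxylic acid would side with compound 3 or with compound 4. Also open, as far as these compounds go, is whether the fluoro step holds at other carbons of the ring or alongside the methyl group on the chain of compound 2.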